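The compounds below may be only part of what the source reports. "The series", "measured", "known", "first", "only" and "open" are said of these compounds alone.

Measured compounds:
- compound 1 `N#Cc1ccc(CN(C(=O)Nc2cc(C(F)(F)F)cc(C(F)(F)F)c2)n2cnnc2)cc1`: 7220 nM
- compound 2 `Cc1ccc(NC(=O)N(Cc2ccccn2)n2cnnc2)cc1`: 38900 nM
- compound 3 `Cc1ccsc1CN(C(=O)Nc1cccc(C#N)c1)n1cnnc1`: > 50000 nM

In a functional assay on MCF7 cells (Homo sapiens) for cytotoxicity, read by MTT assay, with a stated time of 48 h (on this read-out higher numbers stand for weaker inhibition and lower numbers for stronger inhibition), compound 1 gives 7220 nM and stands at the lowest of the two numbers shown. Compound 2 gives 38900 nM, a higher number that lies beyond the scatter. Compound 3 reaches only a limit of this assay, > 50000 nM. One of the three values thus sits at the limit of > 50000 nM in this assay, at which 1 of the 3 values shown sits, rather than at a number.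

Compound 4 `COc1cc(CN(C(=O)Nc2cc(C(F)(F)F)cc(C(F)(F)F)c2)n2cnnc2)cc(OC)c1OC` differs from compound 1 in one place: 3,4,5-trimethoxyphenyl in place of 4-cyanophenyl on a saturated chain carbon bound to an amide-type nitrogen. Among the measured compounds shown here, no measured pair in the set covers this change, so the step cannot be read from the data. The expectation for this assay is a modest move toward a lower number, close to the scatter. Compound 4 is estimated at 4000 nM, within 800 nM to 20000 nM. That estimate means an expected step of a 1.8-fold lower number from compound 1 to compound 4 (0.26 log units; within the scatter).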

Compound 4, half-maximal inhibitory concentration: 23800 nM
Compound 4: middle estimate off by 6.0-fold (0.77 log units), on the low side; measured number above the stated range.
By their numbers in this assay, from the lowest: compound 1; then compounds 4 and 2 (each within the scatter of the next). At a limit, above all of these: compound 3.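

On the saturated chain carbon bound to an amide-type nitrogen, the group carried does bear on the read-out: in this assay, 3,4,5-trimethoxyphenyl in place of 4-cyanophenyl gives a 3.3-fold higher number from compound 1 to compound 4 (0.52 log units; beyond the scatter). Among the compounds shown here, this is the first one-place comparison, and it favours 4-cyanophenyl of these two groups. No measurement shown gives a cause for this step.

On these data alone, whether the step follows from gaining the methoxy groups or from losing the nitrile stays open. Also open, as far as these compounds go, is how a phenyl ring carrying an amine or a carboxylic acid would read at this place.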